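Anilino to dimethylamino on compound 1

A few compounds are considered here, and "the series" means these few. Any claim that something is new, unique, unknown or untested is made for them only; others in the source may bear on it.

Measured in a physicochemical assay for solubility, with a stated time of 24 h, at pH 6.8; a lower number here means a less soluble compound, a higher number a more soluble compound
compound 1 `COC(=O)c1ccc2c(C(=O)Nc3ccccc3)cn(C)c2c1` gives < 1 ug/mL
compound 2 `COC(=O)c1ccc2c(ccn2C(=O)c2ccccc2)c1` gives < 1 ug/mL

Compound 1 gives < 1 ug/mL as a limit of the assay and not a number. Compound 2 gives < 1 ug/mL as a limit too. Among the measured compounds shown here, the only measured evidence is the limit of < 1 ug/mL in this assay, at which 2 of the 2 values shown sit, and the series holds no measured step. Compound 3 `COC(=O)c1ccc2c(C(=O)N(C)C)cn(C)c2c1` keeps the core of compound 1 and carries dimethylamino in place of anilino on a carbonyl carbon. A rise beyond the scatter in this assay is expected, resting on this structural change alone and therefore uncertain. The expected size of the step is an at least 15-fold higher number from compound 1 to compound 3 (1.17 log units; beyond the scatter) as estimated from that change. For compound 3 the estimated value is 15 ug/mL with an expected range from 2 ug/mL to 80 ug/mL in this measurement.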

Compound 3, solubility: 49 ug/mL
Compound 3: middle estimate off by 3.3-fold (0.51 log units), on the low side; measured number inside the range.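

In this assay, among the compounds shown here, dimethylamino in place of anilino on a carbonyl carbon gives an at least 49-fold higher number from compound 1 to compound 3 (1.69 log units; beyond the scatter), the first measured step. Compound 1 gives < 1 ug/mL, which is a limit of the assay and not a number. The read-out at this position therefore moves with the group on the carbonyl carbon, and compound 3 is the only compound shown that stands clear of the limit: the limit of < 1 ug/mL in this assay, at which 2 of the 3 values shown sit.

The change removes the aromatic ring and the amide hydrogen and shortens the group all at once, and the compounds shown do not separate these parts. Also open, as far as these compounds go, is how a methylamino group or a morpholine on the same carbonyl carbon would read in this assay.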